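A few compounds are considered here, and "the series" means these few. Any claim that something is new, unique, unknown or untested is made for them only; others in the source may bear on it.

Values in a physicochemical assay, with a stated time of 90 min (on this read-out higher numbers stand for an effect only at larger amounts of compound and lower numbers for an effect already at smaller amounts), are as follows:

- compound 1 `C/C(=N\N=C1/SCC(=O)N1Cc1cccc(F)c1)c1cccs1` gives 1360000 nM
- compound 2 `C/C(=N\N=C1/SCC(=O)N1Cc1cccc(Cl)c1)c1cccs1` gives 1160000 nM
- compound 3 `CC(C)=N/N=C1\SCC(=O)N1Cc1ccc(N)cc1` gives 1200000 nM

Compound 2 stands with compound 1 and compound 3 within the usual scatter, so no order can be read among the three. The change now considered leads to compound 4 `C/C(=N\N=C1/SCC(=O)N1Cc1cccc(Cl)c1)c1ccccn1` and places pyridin-2-yl in place of thiophen-2-yl on a carbon with a double bond to nitrogen. Among the compounds with values here, only one measured step is available (a 1.2-fold lower number from compound 1 to compound 2 (0.07 log units; within the scatter)), and it lies within the scatter. That step is chloro in place of fluoro on an aromatic carbon, so it does not touch the group being exchanged. Within the data shown here, no measured pair isolates this exchange. Compound 3 lacks the thiophen-2-yl group, differs elsewhere too, and gives (1200000 nM). A step beyond the scatter is therefore not expected in this assay, and no direction is favoured. The expected change is small (a 1.1-fold lower number from compound 2 to compound 4 (0.02 log units; within the scatter)). For compound 4 the estimated value is 1100000 nM (expected range 500000 nM to 2000000 nM).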

Compound 4, half-maximal effective concentration: 2040000 nM
Estimate against measurement, compound 4: 1.9-fold (0.27 log units) below; measured number above the stated range.
By their numbers in this assay, from the lowest: compounds 2, 3, 1 and 4 (each within the scatter of the next).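

In this assay, within the data shown here, the exchange of thiophen-2-yl for pyridin-2-yl on a carbon with a double bond to nitrogen gives a 1.8-fold higher number from compound 2 to compound 4 (0.25 log units; within the scatter), the first measured pair that isolates this position. A five-membered aromatic ring can therefore give way to a six-membered one here without a step that can be told apart from repeat measurements, so this exchange gives no sign that the read-out depends on which of the two rings is present. No measurement of any property bears on this result.

On these data alone, it remains open whether a group of another kind at this place, such as an amine, a carboxylic acid or a longer chain, would give a step beyond the scatter. As far as these compounds go, it is equally open whether the same exchange would read alike with fluoro rather than chloro on the aromatic carbon.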